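Aryl versus alkyl carbamates in a selenocyanate series

The compounds below may be only part of what the source reports. "The series", "measured", "known", "first", "only" and "open" are said of these compounds alone.

Measured compounds in an ADME assay on BEAS-2B cells (Homo sapiens) for cytotoxicity, read by MTT assay, with a stated time of 72 h; on this read-out higher numbers stand for weaker inhibition of growth and lower numbers for stronger inhibition of growth:
compound 1 `C=CCOC(=O)Nc1ccc([Se]C#N)cc1` gives 21400 nM
compound 2 `Cc1ccc(OC(=O)Nc2ccc([Se]C#N)cc2)cc1` gives 5600 nM
compound 3 `CCOC(=O)Nc1ccc([Se]C#N)cc1` gives 21700 nM

Compound 3 stands at the highest of the three numbers in this assay. Its nearest neighbour is compound 1, with a difference well within the scatter; its furthest is compound 2, which sits beyond the scatter below it.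

The next compound, compound 4 `N#C[Se]c1ccc(NC(=O)Oc2ccccc2)cc1`, differs from compound 3 by phenyl in place of ethyl on an oxygen next to a carbonyl group. For the measured compounds named here, only one measured step bears on this change, and only loosely: the step of a 1.0-fold higher number from compound 1 to compound 3 (0.01 log units; within the scatter) shows that exchanging one small chain for another on that oxygen moved nothing. The move to phenyl is of a different kind, and the most informative comparison is with compound 2, whose oxygen also carries a phenyl ring, here bearing a methyl, and whose value 5600 nM lies well under that of compound 3 at 21700 nM. Going by the values given here, no direct step between compound 2 and compound 3 is available, so the direction is read from those two values alone.

Compound 4 is therefore expected to fall toward compound 2, with a step of a 2.9-fold lower number from compound 3 to compound 4 (0.46 log units; beyond the scatter) estimated. The estimate for compound 4 is 7500 nM, with a range from 3500 nM to 16000 nM.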

Compound 4, concentration for 50% growth inhibition: 8900 nM
Compound 4: middle estimate off by 1.2-fold (0.07 log units), on the low side, within the range that was stated.
By their numbers in this assay, from the lowest: compounds 2 and 4 (each within the scatter of the next); then compounds 1 and 3 (each within the scatter of the next).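

In this assay, for the compounds shown here, phenyl on the oxygen next to a carbonyl group gives the first change at this position that lies beyond the scatter (a 2.4-fold lower number from compound 3 to compound 4 (0.39 log units; beyond the scatter)), whereas exchanging allyl for ethyl did not (a 1.0-fold higher number from compound 1 to compound 3 (0.01 log units; within the scatter)). The comparison with allyl gives a step of similar size (a 2.4-fold lower number from compound 1 to compound 4 (0.38 log units; beyond the scatter)), so the shift is seen against both chains. Hydrogen in place of methyl on the aromatic carbon stays within the scatter (a 1.6-fold higher number from compound 2 to compound 4 (0.20 log units; within the scatter)), so the shift does not depend on that methyl.

No measurement available here accounts for the shift.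

From the compounds shown here alone, it remains open whether the shift follows from the aromatic ring itself or from the larger group on this oxygen, which a cyclohexyl group could separate. A benzyl group would show whether the ring must sit directly on that oxygen.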